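Methoxy for Trifluoromethyl and Liver Cell Toxicity

A few compounds are considered here, and "the series" means these few. Any claim that something is new, unique, unknown or untested is made for them only; others in the source may bear on it.

Three compounds were measured in a toxicity assay on HepG2 cells (Homo sapiens) for inhibition, read by CellTiter-Glo, with a stated time of 48 h; on this read-out lower numbers stand for stronger inhibition and higher numbers for weaker inhibition. Compound 1 `COc1ccc2nc(C)cc(OCC(=O)Nc3cc(C)cc(C)c3)c2c1` gives 20000 nM. Compound 3 `COc1ccc2nc(C)cc(OCC(=O)Nc3ccc(Cl)c(C(F)(F)F)c3)c2c1` gives 79400 nM, the higher of the two numbers. For compound 2 `Cc1cc(C)cc(NC(=O)COc2cc(C)nc3ccc(C(F)(F)F)cc23)c1` the assay reports only a limit, > 100000 nM. The difference between the cores of compound 2 and compound 3 is not broken down here.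

From compound 2 to compound 1 the change is methoxy in place of trifluoromethyl on an aromatic carbon. It gives an at least 5.0-fold lower number from compound 2 to compound 1 (0.69 log units; beyond the scatter), stated as a bound because the limit of > 100000 nM in this assay, at which 1 of the 3 values shown sits, caps the starting value.

Compound 4 `COc1ccc2nc(C)cc(OCC(=O)Nc3ccc(Cl)c(OC)c3)c2c1` has not yet been measured. It differs from compound 3 by methoxy in place of trifluoromethyl on an aromatic carbon. This is the same kind of change as from compound 2 to compound 1, but not the same: there the place is part of a fused or bridged system of two rings, meta to a fused ring and para to a fused ring; here it is ortho to a chloro group and meta to a large group. Resting on the step from compound 2 to compound 1 an at least 5.0-fold lower number from compound 2 to compound 1 (0.69 log units; beyond the scatter) and on the value of compound 3 79400 nM, the expected step is a 2.0-fold lower number from compound 3 to compound 4 (0.30 log units; within the scatter), with wide uncertainty since the place differs. Compound 4 is therefore estimated at 40000 nM, expected between 12000 nM and 130000 nM.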

Compound 4, half-maximal inhibitory concentration in the HepG2 assay: > 100000 nM
Compound 4: no number, only a limit (the forecaster's own chance of this, stated with the estimate: 25%); at least 2.5-fold (0.39 log units) between middle value and limit.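

In the HepG2 assay the change from trifluoromethyl to methoxy does not carry over from one core to the other: the same change on two cores in the HepG2 assay, an at least 5.0-fold lower number (0.69 log units; beyond the scatter) from compound 2 to compound 1 and an at least 1.2-fold higher number (0.10 log units; that floor lies within the scatter) from compound 3 to compound 4, at least 6.2-fold (0.79 log units) apart, beyond the scatter of two such steps. In the HepG2 assay the new step is an at least 1.2-fold higher number from compound 3 to compound 4 (0.10 log units; that floor lies within the scatter), while 4-chloro-3-methoxyphenyl in place of 3,5-dimethylphenyl on an amide-type nitrogen gives an at least 5.0-fold higher number from compound 1 to compound 4 (0.69 log units; beyond the scatter). This does not give the true size of any of these steps, nor a cause for the gap between the cores, as compound 2 and compound 4 are each read only at a limit of the assay: the limit of > 100000 nM in the HepG2 assay, at which 2 of the 4 values shown sit.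

In a physicochemical assay for lipophilicity, read by HPLC, in phosphate buffer, measured as chromatographic lipophilicity, at pH 7.4 (a lower number here means a more polar compound, a higher number a more lipophilic compound), compound 3 gives 6.22 and compound 4 gives 5.09. The compounds shown leave open whether the lower number in the physicochemical assay has any link to the toxicity result, since one pair cannot settle that: the measured distribution coefficient of compound 3, 6.22, and of compound 4, 5.09, a number 1.13 log units lower (beyond the scatter). They also leave open how an amine or a carboxylic acid in place of the methoxy group of compound 4 would read in the HepG2 assay, and whether such a group would give a number rather than a limit.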